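The source may report more compounds than this note shows. Statements on the series, on what has been measured and on what is new or still open speak of the compounds shown alone.

Measured so far in a functional assay on SK-OV-3 cells (Homo sapiens) for inhibition, read by sulforhodamine B assay, with a stated time of 48 h; on this read-out lower numbers stand for higher toxicity in this test and higher numbers for lower toxicity in this test:
compound 1, `COc1cc(-c2nn(-c3cccc(NC(=O)Nc4ccc(Cl)c(Cl)c4)c3)cc2-c2ccncc2)ccc1Cl` — compound 1 gives only a limit here, > 50000 nM.
compound 2, `O=C(Nc1cccc(-n2cc(-c3ccncc3)c(-c3ccc(Cl)c(O)c3)n2)c1)Nc1ccc(Cl)c(Cl)c1` — compound 2 likewise gives only a limit, > 32500 nM.
compound 3, `O=C(Nc1cccc(-n2cc(-c3ccncc3)c(-c3ccc(Cl)c(O)c3)n2)c1)Nc1cc(C(F)(F)F)cc(C(F)(F)F)c1` — compound 3 also gives only a limit, > 50000 nM.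

Compound 1 therefore stands at no number, but at a limit; the two other values shown are limits as well, one sitting at the limit of > 32500 nM in this assay, at which 1 of the 3 values shown sits, and two at the limit of > 50000 nM in this assay, at which 2 of the 3 values shown sit. Going by the values given here, the single step that can be drawn, a step that the two limits leave unreadable from compound 1 to compound 2, joins two limits and its size cannot be read. Compound 2 and compound 3 differ in the aryl group on the urea; both values are limits, so nothing more can be said of that pair.

Compound 4, `COc1cc(-c2nn(-c3cccc(NC(=O)Nc4ccc(Cl)c(C(F)(F)F)c4)c3)cc2-c2ccncc2)ccc1Cl`, differs from compound 1 by trifluoromethyl in place of chloro on an aromatic carbon. Among the compounds with values here, no measured step touches this position, and the one step that exists is itself unreadable, so there is no basis for expecting a change beyond the scatter in this assay. The step from compound 1 to compound 4 is expected to be a number no higher from compound 1 to compound 4 (the limit leaves the size open), that is, no readable step. Compound 4 is thus estimated at 50000 nM, with a range from 20000 nM to 120000 nM, and most likely the assay will again report only a limit.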

Compound 4, concentration lethal to 50% of the cells: > 32500 nM
Compound 4: no number, only a limit (the forecaster's own chance of this, stated with the estimate: 75%); the middle value lies beyond the limit too.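

Compound 1 and compound 4 both give only limits in this assay, so no new step can be read from compound 4, and trifluoromethyl in place of chloro has no readable size. The compounds shown leave open where any of the four true values lies and whether any single change shifts toxicity in this assay.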